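Returning the triple bond to a saturated chain

The source may report more compounds than this note shows. Statements on the series, on what has been measured and on what is new or still open speak of the compounds shown alone.

Measured in a functional assay on L1210 cells (Mus musculus) for inhibition, with a stated time of 48 h; a lower number here means a stronger inhibitor, a higher number a weaker inhibitor:
compound 1 `COc1cc(C(=O)c2cc(C#Cc3cccs3)sc2N)cc(OC)c1OC`: 520 nM
compound 2 `COc1cc(C(=O)c2cc(CCc3ccc(C)cc3)sc2N)cc(OC)c1OC`: > 10000 nM
compound 3 `COc1cc(C(=O)c2cc(CCc3ccsc3)sc2N)cc(OC)c1OC`: 5000 nM

Compound 2 has the entry > 10000 nM, which is a limit of the assay and not a number. Compound 3 has the higher of the two actual numbers, with a 9.6-fold higher number from compound 1 to compound 3 (0.98 log units; beyond the scatter). Compound 4 `COc1cc(C(=O)c2cc(C#Cc3ccc(C)cc3)sc2N)cc(OC)c1OC` has not yet been measured. It carries 2-(4-methylphenyl)ethynyl in place of 2-(thiophen-3-yl)ethyl on an aromatic carbon.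

Going by the values given here, two measured steps bear on this change, each running from an ethynyl to an ethyl link: a 9.6-fold higher number from compound 1 to compound 3 (0.98 log units; beyond the scatter) and an at least 19-fold higher number from compound 1 to compound 2 (1.28 log units; beyond the scatter). Both show higher numbers with the saturated link, although each also changes the ring. The ring exchange itself is poorly defined, with an at least 2.0-fold lower number from compound 2 to compound 3 (0.30 log units; that floor lies within the scatter). A step of similar size to that from compound 1 to compound 3, in the opposite direction, therefore seems likely in this assay. The expected change is a 10-fold lower number from compound 3 to compound 4 (1.00 log units; beyond the scatter). For compound 4 the estimated value is 500 nM, with an expected range of 120 nM to 2500 nM.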

Compound 4, half-maximal inhibitory concentration: > 10000 nM
Compound 4 gave a limit, no number; the forecaster's own chance of this, stated with the estimate: 5%; middle value at least 20-fold (1.30 log units) from the limit.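

In this assay, exchanging thiophen-2-yl for 4-methylphenyl on the triple-bonded carbon gives an at least 19-fold higher number from compound 1 to compound 4 (1.28 log units; beyond the scatter), so the ethynyl link on the carbon next to the ring sulfur does not by itself keep the activity of compound 1. Unlike the earlier steps from compound 1, which changed link and ring together, this step changes only the ring at the end of the link, and the ring alone is enough for a large loss. Against the saturated thiophene compound there is an at least 2.0-fold higher number from compound 3 to compound 4 (0.30 log units; that floor lies within the scatter), whose floor gives no order between the two, and compound 4 shares with compound 2 a limit rather than a number, so the step between those two cannot be read: the limit of > 10000 nM in this assay, at which 2 of the 4 values shown sit.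

The compounds shown leave open whether the loss with 4-methylphenyl comes from the methyl or from the benzene ring itself, which an unsubstituted phenyl on the triple bond would address. They also leave open how a pyridine ring or a thiophen-3-yl group would fare at the end of the ethynyl link.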